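Hydroxymethyl Added to the Lactone Ring of Compound 3

The source may hold more compounds than are shown below. What is called first, only, known or untested is meant among the compounds shown, and "the series" means these compounds.

Of the compounds shown here, three have so far been tested in an ADME assay on BJ cells (Homo sapiens) for cytotoxicity, read by luminescence and ATP content, with a stated time of 48 h; on this read-out higher numbers stand for weaker inhibition and lower numbers for stronger inhibition. Compound 1 `COc1cc(OC)c(C2=C(c3ccc(OC)c(OC)c3OC)COC2=O)c(OC)c1` reaches only the limit of the assay, giving > 40000 nM. Compound 2 `O=C1OCC(c2ccc(C(F)(F)F)cc2)=C1c1c[nH]c2ccccc12` likewise gives a limit rather than a number, > 40000 nM. Compound 3 `COc1ccc(C2=C(c3ccc(OC)c(OC)c3)C(CO)OC2=O)cc1`, the starting point of the step described here, also gives a limit, > 40000 nM. Compound 3 therefore stands where every measured compound stands, and no ordering among the three can be read from these figures because all of them sit at the limit of > 40000 nM in this assay, at which 3 of the 3 values shown sit.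

Compound 4 `COc1ccc(C2=C(c3ccc(OC)c(OC)c3)C(CO)(CO)OC2=O)cc1` has not yet been measured in this assay. It differs from compound 3 by hydroxymethyl in place of hydrogen on a saturated ring carbon. Going by the values given here, no pair of measured compounds differing in one place is available, so no measured step can serve as a guide. Since compound 3 is reported only as a limit, > 40000 nM, a small change of this kind gives no reason to expect a step beyond the scatter. Compound 4 is therefore expected to give 60000 nM, within 30000 nM to 150000 nM, and most likely to be reported again as a limit. The step that the limit leaves unreadable from compound 3 to compound 4 implied by this estimate is expected to be no larger than the usual scatter.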

Compound 4, half-maximal inhibitory concentration: > 40000 nM
Compound 4 gave a limit, no number (the forecaster's own chance of this, stated with the estimate: 85%); the middle value is on the limit's open side.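

Going by these compounds alone, compound 3 and compound 4 both give only a limit, so placing hydroxymethyl in place of hydrogen yields no step that can be read, and all the compounds shown sit at the same point: the limit of > 40000 nM in this assay, at which 4 of the 4 values shown sit.

In this assay the compounds shown leave open whether hydroxymethyl on this saturated ring carbon changes cytotoxicity at all.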